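Methoxy in place of chloro on compound 2

The source may hold more compounds than are shown below. What is called first, only, known or untested is meant among the compounds shown, and "the series" means these compounds.

In a functional assay on HCT-116 cells (Homo sapiens) for inhibition, read by MTT assay, with a stated time of 72 h, in the presence of a further agent that is not named here (a higher number here means that more compound is needed for the effect, a lower number that less compound is needed), compound 2 `O=C(Nc1cc(Cl)nc(Cl)c1)Nc1cc(Cl)nc(Cl)c1` holds the lower of the two numbers at 180 nM while compound 1 `O=C(Nc1ccnc(Cl)c1)Nc1cc(Cl)nc(Cl)c1` stands at 16100 nM on the same read-out. Among the measured compounds shown here, the one measured step of an 89-fold lower number from compound 1 to compound 2 (1.95 log units; beyond the scatter) lies beyond the scatter and is large, with chloro in place of hydrogen on an aromatic carbon. Compound 3 `COc1cc(NC(=O)Nc2cc(Cl)nc(Cl)c2)cc(Cl)n1` has methoxy in place of chloro on an aromatic carbon, next to the ring nitrogen (methoxy in place of chloro on an aromatic carbon). For the measured compounds named here, no compound with methoxy has been measured, so that single step is the only guide. Part of an 89-fold lower number from compound 1 to compound 2 (1.95 log units; beyond the scatter) is expected to be lost in this assay as a higher number, with a 5.6-fold higher number from compound 2 to compound 3 (0.74 log units; beyond the scatter) as the estimated step overall. Compound 3 is estimated at 1000 nM with a range from 200 nM to 6000 nM on this read-out.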

Compound 3, half-maximal effective concentration: 11200 nM
Estimate against measurement, compound 3: 11-fold (1.05 log units) below, and the stated range ends below it.
By their numbers in this assay, from the lowest: compound 2; then compounds 3 and 1 (each within the scatter of the next).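

In this assay, the position next to the ring nitrogen responds to which group it carries and not merely to being substituted, as methoxy in place of chloro gives a 62-fold higher number from compound 2 to compound 3 (1.79 log units; beyond the scatter) in this series. Methoxy in place of hydrogen gives a 1.4-fold lower number from compound 1 to compound 3 (0.16 log units; within the scatter) here, so of the two groups seen at this position, only chloro separates from hydrogen. Nothing at hand bears on the cause of this difference. Going by these compounds, whether bromo, methyl or an amine at this position would behave like chloro or like methoxy remains open.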